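The compounds below may be only part of what the source reports. "The series", "measured", "known", "first", "only" and "open" are said of these compounds alone.

Compound 1 `CCOC(=O)c1c(-c2cccc(Oc3ccccc3)c2)[nH]c2cc(OC)ccc2c1=O`: 750 10^-6 cm/s
Compound 2 `CCOC(=O)c1c(-c2cccc(Oc3ccccc3)c2)[nH]c2cc(OC)c(F)cc2c1=O`: 560 10^-6 cm/s

In an ADME assay for permeability, using PAMPA, at pH 7.4 (on this read-out higher numbers stand for higher permeability and lower numbers for lower permeability), compound 2 stands at 560 10^-6 cm/s, within the scatter of compound 1. Compound 3 `COc1cc2[nH]c(-c3cccc(Oc4ccccc4)c3)c(C(=O)OCCO)c(=O)c2cc1F` is made from compound 2 by one change, (hydroxy in place of hydrogen on a saturated chain carbon, two bonds along the chain from an oxygen next to a carbonyl group), which turns the ethoxy of the ester into 2-hydroxyethoxy. Going by the values given here, only one measured step exists, a 1.3-fold lower number from compound 1 to compound 2 (0.13 log units; within the scatter). It is fluoro in place of hydrogen on an aromatic carbon, a different change that leaves the chain untouched, so it gives no size for this one. Among the compounds with values here, no measured compound carries a hydroxy on that chain. The expectation therefore rests on the structural change alone and is uncertain: a lower number in this assay, beyond the scatter. The expected step is a 2.8-fold lower number from compound 2 to compound 3 (0.45 log units; beyond the scatter). For compound 3 the estimated value is 200 10^-6 cm/s, with an expected range from 60 10^-6 cm/s to 500 10^-6 cm/s.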

Compound 3, apparent permeability: 620 10^-6 cm/s
The estimate for compound 3 lay 3.1-fold (0.49 log units) below the measured number; the measured number lies above the stated range.
By their numbers in this assay, from the lowest: compounds 2, 3 and 1 (each within the scatter of the next).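

In this assay, going by these compounds alone, replacing the ethoxy of the ester with 2-hydroxyethoxy gives a 1.1-fold higher number from compound 2 to compound 3 (0.04 log units; within the scatter) and is the first measured change on this chain, since the earlier step concerned only an aromatic carbon. It shows that, on the core of compound 2, this position can carry a hydroxy with no difference in the read-out beyond the scatter. Nothing measured here bears on why the number holds.

Still open, as far as these compounds go, is whether the same would hold for an amine on this chain, for a longer chain such as 3-hydroxypropoxy, or for a carboxylic acid in place of the ester. Also open, from the compounds shown here alone, is whether the hydroxy would behave the same way on compound 1, which lacks the fluoro, and what it does in any read-out other than this assay on these compounds.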